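This account rests on a few compounds, and the source may have more. Where it says the series, first, only, none or still open, it means among the compounds named here.

Working notes on the series. In a functional assay on MKN-74 cells (Homo sapiens) for antiproliferative activity, with a stated time of 24 h (a lower number here means a stronger inhibitor, a higher number a weaker inhibitor), compound 1 `NC(=O)c1c(NC(=O)c2ccccc2Cl)sc2c1CCN(C(=S)Nc1ccccc1)C2` gives 15600 nM, compound 2 `NC(=O)c1c(NC(=O)c2ccccc2Cl)sc2c1CCN(C(=S)Nc1ccccc1F)C2` gives 12600 nM and compound 3 `NC(=O)c1c(NC(=O)c2ccccc2Cl)sc2c1CCN(C(=S)Nc1ccccc1Br)C2` gives 10800 nM. Compound 3 holds the lowest of the three numbers, but its steps from the other two stay within the scatter: a 1.4-fold lower number from compound 1 to compound 3 (0.16 log units; within the scatter) and a 1.2-fold lower number from compound 2 to compound 3 (0.07 log units; within the scatter). Compound 4 `NC(=O)c1c(NC(=O)c2ccccc2Cl)sc2c1CCN(C(=S)Nc1ccccc1C(F)(F)F)C2` differs from compound 3 by trifluoromethyl in place of bromo on an aromatic carbon. The measured steps that bear on this change are those that exchange the group on an aromatic carbon: a 1.2-fold lower number from compound 1 to compound 2 (0.09 log units; within the scatter), a 1.4-fold lower number from compound 1 to compound 3 (0.16 log units; within the scatter) and a 1.2-fold lower number from compound 2 to compound 3 (0.07 log units; within the scatter), none of them beyond the scatter. In this assay the expected step is therefore a 1.1-fold lower number from compound 3 to compound 4 (0.03 log units; within the scatter), nothing beyond the scatter. Compound 4 is estimated at 10000 nM, with a range from 4000 nM to 25000 nM.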

Compound 4, half-maximal inhibitory concentration: 1870 nM
Beside the measured number, compound 4's estimate is 5.3-fold (0.73 log units) above it, outside the stated range (below it).
By their numbers in this assay, from the lowest: compound 4; then compounds 3, 2 and 1 (each within the scatter of the next).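

Trifluoromethyl is the first group on this aromatic carbon to move the number in this assay beyond the scatter, with a 5.8-fold lower number from compound 3 to compound 4 (0.76 log units; beyond the scatter) and a 6.7-fold lower number from compound 2 to compound 4 (0.83 log units; beyond the scatter) and an 8.3-fold lower number from compound 1 to compound 4 (0.92 log units; beyond the scatter) in this series. Hydrogen, fluoro and bromo stay within the scatter of one another here, so this place responds to one exchange and not to all of them. Nothing available here accounts for the step.

Open, from the compounds shown here alone, is whether a nitrile, a methoxy group or an amine on this carbon would give a similar step. Also open, going by these compounds, is whether trifluoromethyl would do the same on another carbon of the ring.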